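The compounds below may be only part of what the source reports. "The series", "measured", "known", "first", "only" and "open" are said of these compounds alone.

In an assay on Sf9 cells for inhibition of histone deacetylase 11 (Homo sapiens), read by fluorescence, tested at 0.5 uM (on this read-out lower numbers stand for less inhibition and higher numbers for more inhibition at the one concentration tested (going by the name of the read-out)), compound 1 `O=C(NO)c1cccc(-c2cn([C@H]3C[C@H](C(=O)O)N(CCCc4ccccc4)C3)nn2)c1` gives only a limit of the assay, < 10%. Compound 2 `O=C(NO)c1cccc(-c2cn([C@@H]3C[C@@H](CO)N(CCCc4ccccc4)C3)nn2)c1` likewise gives only a limit there, < 10%. So compound 2 stands at the floor of the numbers shown, as does every value so far, which is what the limit of < 10% in this assay, at which 2 of the 2 values shown sit, records. Compound 3 `O=C(NO)c1cccc(-c2cn([C@@H]3C[C@@H](C(=O)O)N(CCCc4ccccc4)C3)nn2)c1` differs from compound 2 by carboxy in place of hydroxymethyl on a saturated ring carbon: the hydroxymethyl leaves and a carboxy enters. Within the data shown here, no step between measured compounds exists to guide this change, so the step from compound 2 to compound 3 is expected to be none beyond the scatter, a step that the limit leaves unreadable from compound 2 to compound 3. Compound 3 is estimated at 5%, ranging from 0% to 15%.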

Compound 3, a percentage reported as inhibition, at one concentration (the size of the read-out at that concentration, not a potency): < 10%
Compound 3: no number, only a limit; the forecaster's own chance of this, stated with the estimate: 80%; the middle value is on the limit's open side.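

No step can be read among compound 1, compound 2 and compound 3, because each gives only a limit: the limit of < 10% in this assay, at which 3 of the 3 values shown sit.

Going by these compounds, whether carboxy in place of hydroxymethyl, or the inverted configuration, changes the result in this assay stays open.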